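This account rests on a few compounds, and the source may have more. Where it says the series, first, only, none or still open, it means among the compounds named here.

Measured so far in a functional assay on QGY7701 cells (Homo sapiens) for cytotoxicity, read by MTT assay, with a stated time of 48 h; on this read-out lower numbers stand for stronger inhibition and higher numbers for weaker inhibition:

Compound 1, `Cc1ccc(Cn2cc(COc3ccc4c(=O)ccoc4c3)nn2)cc1`, gives 68500 nM.
Compound 2, `O=c1ccoc2cc(OCc3cn(Cc4cccc(Br)c4)nn3)ccc12`, gives 17600 nM.
Compound 3, `O=c1ccoc2cc(OCc3cn(Cc4ccc(F)cc4)nn3)ccc12`, gives 14400 nM.

Among these three numbers compound 2 stands second highest. Its nearest neighbour is compound 3, and that gap, a 1.2-fold lower number from compound 2 to compound 3 (0.09 log units; within the scatter), lies within the scatter, so the two cannot be ordered. Its furthest neighbour is compound 1, and that step, a 3.9-fold lower number from compound 1 to compound 2 (0.59 log units; beyond the scatter), lies beyond the scatter.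

The compound still to be measured is compound 4, `O=c1ccoc2cc(OCc3cn(Cc4ccc(Br)cc4)nn3)ccc12`. It differs from compound 2 in one place: 4-bromophenyl in place of 3-bromophenyl on a saturated chain carbon bound to an aromatic nitrogen.

Going by the values given here, no measured pair moves a bromine from one position on the ring to another, so no step speaks directly to this change. Among the compounds with values here, what does bear on it is that compound 2 and compound 3 sit within the scatter of each other, and that compound 1, the only compound well apart, differs from compound 3 by a 4.8-fold lower number from compound 1 to compound 3 (0.68 log units; beyond the scatter), an exchange of substituent rather than of position. On this footing the bromine's move is expected to bring no step beyond the scatter in this assay, the estimated step being a 1.2-fold lower number from compound 2 to compound 4 (0.07 log units; within the scatter).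

Compound 4 is therefore expected to give about 15000 nM in this assay, with a likely range from 6000 nM to 38000 nM.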

Compound 4, half-maximal inhibitory concentration: 96400 nM
Estimate against measurement, compound 4: 6.4-fold (0.81 log units) below, outside the stated range (above it).
By their numbers in this assay, from the lowest: compounds 3 and 2 (each within the scatter of the next); then compounds 1 and 4 (each within the scatter of the next).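

In this assay, moving the bromine alone, with the same atoms joined differently, gives a 5.5-fold higher number from compound 2 to compound 4 (0.74 log units; beyond the scatter), so 3-bromobenzyl and 4-bromobenzyl are not interchangeable here and the position of this substituent can count for as much as its identity. Among the compounds carrying a group at that ring position, the exchange of substituent no longer reads one way: bromo in place of fluoro gives a 6.7-fold higher number from compound 3 to compound 4 (0.83 log units; beyond the scatter), whereas bromo in place of methyl gives a 1.4-fold higher number from compound 1 to compound 4 (0.15 log units; within the scatter), which leaves compound 1 and compound 4 unordered at the weak end of the series. The data shown offer no measured basis for explaining why the bromine's position matters so much in this assay.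

On these data alone, whether position matters in the same way for fluoro or methyl stays open, as each appears here at one ring position only, so the effect of the move is known for bromine alone. As far as these compounds go, how a chloro, a methoxy or an amine on the same ring would fall also remains unknown.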